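The compounds below may be only part of what the source reports. "The series", "measured", "known", "first", "only" and "open" are said of these compounds alone.

Compound 1 `O=C(Nc1cc(C(F)(F)F)cc(C(F)(F)F)c1)c1cnc(Cl)nc1C(F)(F)C(F)(F)F` is the anchor of this small set. Among the compounds with values here, in an assay on Jurkat cells for activation of nuclear factor NF-kappa-B complex (Homo sapiens) (a higher number here means a weaker inhibitor, a lower number a stronger inhibitor), compound 1 gives 800 nM, and that is the only number reported among the three measured compounds. Compound 2 `O=C(Nc1cc(C(F)(F)F)cc(C(F)(F)F)c1)c1cnc(C(F)(F)F)nc1Cl` returns in this assay a value of > 10000 nM, which is a limit of the assay and not a number. Compound 3 `O=C(Nc1cc(C(F)(F)F)cc(C(F)(F)F)c1)c1cnc(-c2ccccc2)nc1` likewise returns in this assay a value of > 10000 nM, again a limit of the assay. Within the data shown here, two of the three measured values thus sit at the limit of > 10000 nM in this assay, at which 2 of the 3 values shown sit, and the set holds no pair of measured compounds that differ in a single place, so no measured step can be drawn from it.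

Compound 4 `O=C(Nc1cc(C(F)(F)F)cc(C(F)(F)F)c1)c1cnc(Cl)nc1-c1cccs1` has not yet been measured. It differs from compound 1 in one place: thiophen-2-yl in place of 1,1,2,2,2-pentafluoroethyl on an aromatic carbon. Nothing in the measured compounds shows what this exchange does in this assay, so the expectation rests on compound 1 alone, with the limits of compounds 2 and 3 as a caution. The step of a 2.5-fold higher number from compound 1 to compound 4 (0.40 log units; beyond the scatter) is expected to run toward weaker inhibition, modestly beyond the usual scatter. Compound 4 is accordingly estimated at 2000 nM in this assay, within a range from 400 nM to 10000 nM, with a fair chance that only a limit is reported.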

Compound 4, half-maximal inhibitory concentration: 9800 nM
Compound 4: the middle estimate sits 4.9-fold (0.69 log units) below what was measured, within the range that was stated.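

In this assay, within the data shown here, this position now shows for the first time that it responds to a change: when thiophen-2-yl replaces 1,1,2,2,2-pentafluoroethyl on the aromatic carbon next to the ring nitrogen, the result is a 12-fold higher number from compound 1 to compound 4 (1.09 log units; beyond the scatter). The position is therefore not indifferent to what it carries, and thiophen-2-yl there does not keep the strength of compound 1, although compound 4 still returns a true number, 9800 nM. Compound 2 and compound 3 each stand at a limit of the assay and not at a number, so this is the only measured comparison so far: the limit of > 10000 nM in this assay, at which 2 of the 4 values shown sit.

On these data alone, a single pair cannot separate the loss of the fluorinated chain from the arrival of the five-membered ring, so it remains open which of the two exchanges drives the step. As far as these compounds go, it also remains open how this carbon would respond to an ethyl chain, a cyclic amine such as morpholine or a carboxylic acid, and whether any group there could match or improve on compound 1.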